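Cyclohexyl amide in a cytotoxicity series without an anchor

A few compounds are considered here, and "the series" means these few. Any claim that something is new, unique, unknown or untested is made for them only; others in the source may bear on it.

Compound 1 `N[C@H]1CC[C@H](Nc2c(C(=O)NCc3ccc(Cl)cc3Cl)nc(Br)c3cccnc23)CC1` has no single number in a functional assay on MCF7 cells (Homo sapiens) for cytotoxicity, read by MTT assay, with a stated time of 72 h; on this read-out higher numbers stand for weaker inhibition and lower numbers for stronger inhibition: in this assay compound 1 is recorded as "not determined" (no result reported). Going by the values given here, the only measured member of the set is compound 2 `CS(=O)(=O)NCCCCCCN(c1nc(C(=O)NCc2ccc(F)cc2)c(O)c2ncccc12)S(C)(=O)=O`, and in this assay compound 2 gives 7000 nM; it is not a single-change neighbour of compound 1, so its value shows only roughly where compounds of this kind sit. Compound 3 `N[C@H]1CC[C@H](Nc2c(C(=O)NC3CCCCC3)nc(Br)c3cccnc23)CC1` differs from compound 1 by cyclohexyl in place of 2,4-dichlorobenzyl on an amide-type nitrogen. Among the compounds with values here, with no measured value for compound 1 and no measured step of this kind, the direction of the change cannot be read from the data; the step from compound 1 to compound 3 is expected to stay within the usual scatter of this assay, with the value of compound 2 as the only guide to the level. Compound 3 is therefore expected to give about 6000 nM in this assay, with a plausible range from 1500 nM to 25000 nM.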

Compound 3, half-maximal inhibitory concentration: 5200 nM
Compound 3: the middle estimate sits 1.2-fold (0.06 log units) above what was measured; the range from low to high includes it.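

In this assay, going by these compounds alone, compound 3 gives 5200 nM while compound 1 has no single number, so no step between them can be read. Going by these compounds, whether cyclohexyl or 2,4-dichlorobenzyl on the amide-type nitrogen goes with stronger inhibition stays open, and no evidence on hand bears on this result.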